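The source may report more compounds than this note shows. Statements on the series, on what has been measured and on what is new or still open speak of the compounds shown alone.

Measured compounds:
- compound 1, `CCc1nc2nc(C)cc(Nc3cccc(Cl)c3)n2n1`: 170000 nM
- compound 2, `CCC(F)(F)c1nc2nc(C)cc(Nc3ccc(S(F)(F)(F)(F)F)cc3)n2n1`: 15000 nM
- compound 3, `Cc1cc(Nc2ccc(C(F)(F)F)cc2)n2nc(CCO)nc2n1`: 19000 nM

All three were tested in a physicochemical assay for solubility, at pH 6.5; a higher number here means a more soluble compound, a lower number a less soluble compound. Compound 2 and compound 3 sit close together, with the gap between them inside the usual scatter of repeated measurements, so neither can be called more or less soluble than the other. Compound 1 stands apart: its number lies well beyond the scatter above that of compound 2, and it differs from compound 2 in several places at once, so no single change can be read out of that gap.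

Compound 4, `Cc1cc(Nc2ccc(S(F)(F)(F)(F)F)cc2)n2nc(C(F)(F)F)nc2n1`, has not yet been measured in this assay. It is built from compound 2 by one change: fluoro in place of ethyl on a saturated chain carbon bound to an aromatic carbon and two fluorine atoms. For the measured compounds named here, no step between measured compounds isolates this change, so there is nothing directly comparable to lean on. Compound 4 is therefore expected to stay near compound 2, with a step of a 1.5-fold higher number from compound 2 to compound 4 (0.17 log units; within the scatter), which is no larger than the scatter. The estimate for compound 4 is 22000 nM, with a range from 8000 nM to 60000 nM.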

Compound 4, solubility: 30000 nM
Estimate against measurement, compound 4: 1.4-fold (0.13 log units) below; the range from low to high includes it.
By their numbers in this assay, from the lowest: compounds 2, 3 and 4 (each within the scatter of the next); then compound 1.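

For the compounds shown here, replacing 1,1-difluoropropyl with trifluoromethyl gives the first comparison in this assay that isolates a single place, with a 2.0-fold higher number from compound 2 to compound 4 (0.30 log units; within the scatter). At this saturated chain carbon bound to an aromatic carbon and two fluorine atoms, compound 2 and compound 4 therefore cannot be told apart, even though fluoro stands where ethyl stood. Nothing measured here explains why this pair reads as it does.

The compounds shown leave open whether an amine, a carboxylic acid or a longer chain in this place would also stay within the scatter of compound 2. Also open, going by these compounds, is whether the same exchange would read alike with a different group on the aniline ring, a question that compound 1 and compound 3 cannot settle, as each differs from this pair in more than one place.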